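Swapping an aromatic thiourea tail for an aliphatic ketone chain

A few compounds are considered here, and "the series" means these few. Any claim that something is new, unique, unknown or untested is made for them only; others in the source may bear on it.

Compound 1: `CCCn1c(=O)c2nc(-c3ccc(OCC(=O)NCCN=C(S)Nc4ccc(OC)cc4)cc3)[nH]c2n(CCC)c1=O` gives 33.2 nM
Compound 2: `CCCn1c(=O)c2nc(-c3ccc(OCC(=O)NCCN=C(S)Nc4ccc(S(=O)(=O)O)cc4)cc3)[nH]c2n(CCC)c1=O` gives 367 nM
Compound 3: `CCCn1c(=O)c2nc(-c3ccc(OCC(=O)NCCNS(=O)(=O)c4cccc(S(=O)(=O)Cl)c4)cc3)[nH]c2n(CCC)c1=O` gives 2.5 nM

These three compounds share one core and differ only in the tail that hangs from the side chain. In an assay on brain for binding affinity to adenosine receptor A1 (Rattus norvegicus), read by radioligand binding (on this read-out lower numbers stand for stronger inhibition and higher numbers for weaker inhibition), compound 1 stands second highest of the three numbers: compound 2 sits at an 11-fold higher number from compound 1 to compound 2 (1.04 log units; beyond the scatter), while compound 3 gives a number well below that of compound 1, so the tail clearly matters.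

Compound 4, `CCCn1c(=O)c2nc(-c3ccc(OCC(=O)NCCNC(=O)CCCCC(C)=O)cc3)[nH]c2n(CCC)c1=O`, has not been measured. It differs from compound 1 by a group of 10 heavy atoms (7 carbon, 1 nitrogen, 2 oxygen; no ring) in place of a group of 12 heavy atoms (8 carbon, 2 nitrogen, 1 oxygen, 1 sulfur; one six-membered aromatic ring of carbon only), on a saturated chain carbon, two bonds along the chain from an amide-type nitrogen. Within the data shown here, the one measured step, an 11-fold higher number from compound 1 to compound 2 (1.04 log units; beyond the scatter), swaps a substituent on the aromatic ring that is now removed altogether, so it bears only loosely on this change. Among the measured compounds shown here, no measured pair shows the loss of the ring itself, and the two measured tails without that ring do not exist here. What can be said is that every tail tested so far keeps an aromatic ring and the numbers spread widely across them.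

The expectation for compound 4 is therefore a modest weakening, a 1.8-fold higher number from compound 1 to compound 4 (0.26 log units; within the scatter), with wide uncertainty. The estimated value for compound 4 in this assay is 60 nM, expected to lie between 15 nM and 250 nM.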

Compound 4, inhibition constant: 44 nM
Compound 4: middle estimate off by 1.4-fold (0.13 log units), on the high side; the range from low to high includes it.
By their numbers in this assay, from the lowest: compound 3; then compounds 1 and 4 (each within the scatter of the next); then compound 2.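

The tail of compound 1 can lose its aromatic ring altogether without a clear change in this assay: with ((4-acetylbutyl)carbonyl)amino in its place, the step is a 1.3-fold higher number from compound 1 to compound 4 (0.12 log units; within the scatter). Among these compounds, all the earlier tails carried an aromatic ring, so this is the first sign that such a ring is not needed at this position for a number of this size, and that a ringless chain ending in a ketone can serve there too. Among the compounds shown here, by contrast, the single swap on the ring gave an 11-fold higher number from compound 1 to compound 2 (1.04 log units; beyond the scatter), so a change at one ring carbon moved the number clearly, while replacing the whole group did not, and no measured evidence offers an explanation for this.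

The change from compound 1 to compound 4 alters the ring, the thiourea and the chain end at once, so the compounds shown cannot say what each part contributes. It also remains open how far this tolerance extends, since no tail shown ends in a carboxylic acid or an amine, and none is a longer chain.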